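From Carbonylamino Acid to Carboxyethenyl Acid

The compounds below may be only part of what the source reports. "The series", "measured", "known", "first", "only" and "open" are said of these compounds alone.

In a physicochemical assay for lipophilicity, using the shake flask method (a higher number here means a more lipophilic compound, a lower number a more polar compound), compound 1 `C[C@H](Oc1ccc(NC(=O)CC(=O)O)c(C2CC2)c1)c1c(Cl)ccc(F)c1Cl` gives 1.9, the lower of the two actual numbers, and compound 2 `C[C@H](Oc1ccc2ncc(/C=C/c3nn[nH]n3)c(C3CC3)c2c1)c1c(Cl)ccc(F)c1Cl` gives 3.7. Compound 3 `C[C@H](Oc1ccc2ncc(/C=C/C(N)=O)c(C3CC3)c2c1)c1c(Cl)ccc(F)c1Cl` reaches only a limit, > 5.5. Compound 4 `C[C@H](Oc1ccc(/C=C/C(=O)O)c(C2CC2)c1)c1c(Cl)ccc(F)c1Cl` departs from compound 1 at one place 2-carboxyethenyl in place of ((carboxymethyl)carbonyl)amino on an aromatic carbon: 2-carboxyethenyl stands in place of ((carboxymethyl)carbonyl)amino on an aromatic carbon, ortho to a cyclopropyl group. For the measured compounds named here, the only measured step, a number at least 1.80 log units higher from compound 2 to compound 3 (beyond the scatter), is large, but it exchanges 2H-tetrazol-5-yl for carbamoyl on a different core and bears only loosely here. Both groups in the present change carry a carboxy end, so a much smaller upward step is expected, a number 0.70 log units higher from compound 1 to compound 4 (beyond the scatter). For compound 4 the estimated value is 2.6, within an expected range of 1.9 to 3.4.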

Compound 4, distribution coefficient: 3.6
Estimate against measurement, compound 4: 1.00 log units below, outside the stated range (above it).
By their numbers in this assay, from the lowest: compound 1; then compounds 4 and 2 (each within the scatter of the next). At a limit, above all of these: compound 3.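

In this assay, the exchange on this aromatic carbon, ortho to a cyclopropyl group, gives a number 1.70 log units higher from compound 1 to compound 4 (beyond the scatter), a large step. Both groups end in a carboxy unit, so a carboxy end shared across the change does not keep the numbers close; the leaving group holds a nitrogen, and the entering group holds none. Nothing measured here gives a cause for this step.

The compounds shown leave open where a saturated 2-carboxyethyl chain or a longer chain ending in a carboxylic acid would fall at this position. They also leave open whether the same exchange would give a similar step on another core.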